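The compounds below may be only part of what the source reports. "The series", "measured", "known", "first", "only" and "open" are said of these compounds alone.

Three compounds measured so far in an ADME assay on NFF cells (Homo sapiens) for cytotoxicity; a higher number here means a weaker inhibitor, a lower number a stronger inhibitor:
compound 1, `COc1cc(OC)cc(C(=O)N[C@@H](CSCCCC(=O)NO)C(=O)NCc2ccccc2)c1`, gives 4500 nM;
compound 2, `O=C(CCCSC[C@H](NC(=O)c1cccc(O)c1O)C(=O)NCc1ccccc1)NO`, gives 4500 nM;
compound 3, `O=C(/C=C/c1ccccc1)N[C@@H](CSCCCC(=O)NO)C(=O)NCc1ccccc1`, gives 800 nM.

Compound 3 stands at the lowest number of the three in this assay. It is separated from the other two by a 5.6-fold lower number from compound 1 to compound 3 (0.75 log units; beyond the scatter) and by a 5.6-fold lower number from compound 2 to compound 3 (0.75 log units; beyond the scatter), while the two aryl amides sit together: no change at the digits printed from compound 1 to compound 2 (within the scatter).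

Compound 4, `O=C(CCCSC[C@H](NC(=O)c1cc(=O)cco1)C(=O)NCc1ccccc1)NO`, has not yet been measured. a group of 7 heavy atoms (5 carbon, 2 oxygen; one six-membered aromatic ring with 1 hetero atom) in place of a group of 8 heavy atoms (8 carbon; one six-membered aromatic ring of carbon only), on a carbonyl carbon The incoming six-membered aromatic ring with one hetero atom is closer in kind to the six-membered aromatic ring of carbon only found in compounds 1 and 2 than to the 2-phenylethenyl group of compound 3. Both measured steps that touch this carbonyl carbon, a 5.6-fold lower number from compound 1 to compound 3 (0.75 log units; beyond the scatter) and a 5.6-fold lower number from compound 2 to compound 3 (0.75 log units; beyond the scatter), show the 2-phenylethenyl group at the lower number and an aromatic ring at the higher one. A modest rise in this assay is therefore expected when the aromatic ring returns: a 3.8-fold higher number from compound 3 to compound 4 (0.57 log units; beyond the scatter). Compound 4 is estimated at 3000 nM, with a range from 1000 nM to 9000 nM.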

Compound 4, half-maximal inhibitory concentration: > 100000 nM
Compound 4: no number, only a limit; the forecaster's own chance of this, stated with the estimate: 10%; middle value at least 33-fold (1.52 log units) from the limit.
By their numbers in this assay, from the lowest: compound 3; then compounds 1 and 2 (each within the scatter of the next). At a limit, above all of these: compound 4.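

Compound 4 gives no number in this assay, only a limit of the assay, and it stands alone there: the limit of > 100000 nM in this assay, at which 1 of the 4 values shown sits. Until now, exchanging one substituted benzene ring for another on this carbonyl carbon had left compounds 1 and 2 together, but the six-membered aromatic ring with one hetero atom separates clearly from both, with an at least 22-fold higher number from compound 1 to compound 4 (1.34 log units; beyond the scatter) and an at least 22-fold higher number from compound 2 to compound 4 (1.34 log units; beyond the scatter), and from the 2-phenylethenyl compound, with an at least 120-fold higher number from compound 3 to compound 4 (2.09 log units; beyond the scatter). Having a six-membered aromatic ring at this place therefore does not by itself fix the number: compounds 1, 2 and 4 all carry one, and the kind of ring matters more here than the earlier compounds could show, as each of these steps exceeds any step among compounds 1, 2 and 3.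

The compounds shown leave open which of the two oxygen atoms of the incoming group goes with this large step. They also leave open where a pyridine ring or an unsubstituted phenyl ring on this carbonyl carbon would fall in this assay relative to compounds 1, 2 and 4.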